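Two Chlorines on the Phenyl Group of Compound 1

The compounds below may be only part of what the source reports. "The series", "measured", "known", "first", "only" and "open" are said of these compounds alone.

Measured so far:
compound 1 `S=c1oc(-c2ccc3c(c2)OCCO3)nn1CNc1ccccc1` gives 5140 nM
compound 2 `S=c1oc(-c2ccc3c(c2)OCCO3)nn1CNc1ccc(Cl)cc1` gives 7270 nM
compound 3 `S=c1oc(-c2ccc3c(c2)OCCO3)nn1CNc1cc(Cl)ccc1Cl` gives 5420 nM

In a functional assay, with a stated time of 6 min (a higher number here means a weaker inhibitor, a lower number a stronger inhibitor), no number shown is smaller than that of compound 1, yet the gaps to its neighbours, a 1.1-fold higher number from compound 1 to compound 3 (0.02 log units; within the scatter) and a 1.4-fold higher number from compound 1 to compound 2 (0.15 log units; within the scatter), stay within the scatter, so the three compounds cannot truly be told apart. Compound 4 `S=c1oc(-c2ccc3c(c2)OCCO3)nn1CNc1ccc(Cl)c(Cl)c1` differs from compound 1 in one place: 3,4-dichlorophenyl in place of phenyl on an amine nitrogen. Within the data shown here, two measured steps bear on this, both putting chlorine on the same phenyl group: a 1.4-fold higher number from compound 1 to compound 2 (0.15 log units; within the scatter) and a 1.1-fold higher number from compound 1 to compound 3 (0.02 log units; within the scatter). Neither leaves the scatter, and nor does a 1.3-fold lower number from compound 2 to compound 3 (0.13 log units; within the scatter). It is therefore expected that a 1.3-fold higher number from compound 1 to compound 4 (0.10 log units; within the scatter), nothing beyond the scatter. Compound 4 is estimated at 6500 nM, most likely between 3000 nM and 14000 nM.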

Compound 4, half-maximal inhibitory concentration: 6840 nM
The estimate for compound 4 lay 1.1-fold (0.02 log units) below the measured number, and the stated range covers the measured number.
By their numbers in this assay, from the lowest: compounds 1, 3, 4 and 2 (each within the scatter of the next).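

In this assay, 3,4-dichlorophenyl in place of phenyl gives a 1.3-fold higher number from compound 1 to compound 4 (0.12 log units; within the scatter), so a second chlorine pattern on this phenyl group also stays within the scatter. Replacing 2,5-dichlorophenyl with 3,4-dichlorophenyl gives a 1.3-fold higher number from compound 3 to compound 4 (0.10 log units; within the scatter), and adding a second chlorine to the 4-chlorophenyl group gives a 1.1-fold lower number from compound 2 to compound 4 (0.03 log units; within the scatter), so neither the placing nor the number of chlorines shown separates these compounds. No measurement here offers a reason for this flat result. On these data alone, it remains open whether a different group on this phenyl ring, such as a methoxy group or a carboxylic acid, would move the number beyond the scatter.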